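Trifluoromethyl for fluoro on the hydroxyphenyl ring

The compounds below may be only part of what the source reports. "The series", "measured", "known", "first", "only" and "open" are said of these compounds alone.

Compound 1 `NC(=O)c1cn(-c2ccc(O)cc2)c2cc(-c3ccncc3)ccc2c1=O` gives 2000 nM in an assay on isolated protein for inhibition of Calpain-1 catalytic subunit (Homo sapiens); on this read-out lower numbers stand for stronger inhibition and higher numbers for weaker inhibition.
Compound 2 `NC(=O)c1cn(-c2ccc(O)cc2F)c2cc(-c3ccncc3)ccc2c1=O` gives 7000 nM in this assay.

Of the two numbers measured, compound 2 stands highest; its nearest neighbour is compound 1, and the step of a 3.5-fold higher number from compound 1 to compound 2 (0.54 log units; beyond the scatter) was a modest one, beyond the scatter. Compound 3 `NC(=O)c1cn(-c2ccc(O)cc2C(F)(F)F)c2cc(-c3ccncc3)ccc2c1=O` has not yet been measured. It differs from compound 2 by trifluoromethyl in place of fluoro on an aromatic carbon, a position described as ortho to a large group and meta to the hydroxy group.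

Among the measured compounds shown here, only one measured step bears on this change, and only loosely: the step of a 3.5-fold higher number from compound 1 to compound 2 (0.54 log units; beyond the scatter) shows that putting a fluoro at this carbon weakened inhibition in this assay by a modest amount. Whether exchanging that fluoro for a trifluoromethyl carries the number further in the same direction, or leaves it within the scatter, cannot be read from the two measured compounds. The estimate for compound 3 is therefore a step of a 1.4-fold higher number from compound 2 to compound 3 (0.15 log units; within the scatter), a small further rise at most. Compound 3 is expected to give about 10000 nM in this assay, with a likely range from 3000 nM to 40000 nM.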

Compound 3, half-maximal inhibitory concentration: 20000 nM
Compound 3: the middle estimate sits 2.0-fold (0.30 log units) below what was measured; low and high end bracket the measured number.
By their numbers in this assay, from the lowest: compound 1; then compound 2; then compound 3.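

The exchange of fluoro for trifluoromethyl on this aromatic carbon gives a 2.9-fold higher number from compound 2 to compound 3 (0.46 log units; beyond the scatter) in this assay and shows that the rise seen with fluoro does not stop there: a second change at the same carbon, from 1 heavy atom to 4, again moves the number beyond the scatter. Measured from the unsubstituted carbon, the whole change amounts to a 10-fold higher number from compound 1 to compound 3 (1.00 log units; beyond the scatter) and is larger than either single step taken on its own. Across these three compounds the number climbs in the order hydrogen, fluoro, trifluoromethyl, none of them goes against that order, and at this carbon compound 1 remains the strongest inhibitor of the three.

Nothing measured here explains why the number rises along this series. From the compounds shown here alone, whether a methyl, a chloro, a methoxy, an amine or a carboxylic acid at this same carbon would fit that order remains open, as does whether trifluoromethyl would have the same effect on any other carbon of the hydroxyphenyl ring.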